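The compounds below may be only part of what the source reports. "The series", "measured", "known", "first", "only" and "open" are said of these compounds alone.

Working notes on the series. In a functional assay on HCT-8 cells (Homo sapiens) for antiproliferative activity, read by MTT assay, with a stated time of 48 h (a lower number here means a stronger inhibitor, a higher number a weaker inhibitor), compound 1 (`COc1ccc2c(/C=C/C(=O)c3cc(N)c(OC)c(OC)c3)cn(C)c2c1`) gives 455 nM, while compound 2 (`COc1ccc2c(/C=C(\C)C(=O)c3cc(OC)c(OC)c([Se]C)c3)cn(C)c2c1`) gives 25 nM. Compound 2 therefore holds the lower of the two numbers, and the gap between them lies beyond the scatter. The two compounds differ at more than one place, so this gap cannot be assigned to any single structural feature. Compound 3 (`COc1ccc2c(/C=C(\C)C(=O)c3cc(OC)c(OC)c([Se]C)c3)c[nH]c2c1`) departs from compound 2 at one place, on an aromatic nitrogen: hydrogen in place of methyl on an aromatic nitrogen. For the measured compounds named here, both measured compounds carry the methyl on that nitrogen, so no measured pair gives a direct size for this change. A modest move toward a weaker number is expected in this assay, with an estimated 2.4-fold higher number from compound 2 to compound 3 (0.38 log units; beyond the scatter), although a result within the scatter remains possible. For compound 3 the estimated value is 60 nM, with an expected range from 15 nM to 250 nM.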

Compound 3, half-maximal inhibitory concentration: 29 nM
Estimate against measurement, compound 3: 2.1-fold (0.32 log units) above; the measured number falls inside the stated range.
By their numbers in this assay, from the lowest: compounds 2 and 3 (each within the scatter of the next); then compound 1.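

In this assay, the exchange of methyl for hydrogen on the aromatic nitrogen now has a direct reading: a 1.2-fold higher number from compound 2 to compound 3 (0.06 log units; within the scatter). With the rest of compound 2 held fixed, the methyl on that nitrogen is therefore not needed for a number in this range, and the free nitrogen-hydrogen form reads the same within the scatter. Nothing available explains this outcome. Still open is how other groups on that nitrogen, such as ethyl, benzyl or acetyl, would read in this series, since the compounds shown carry only methyl or hydrogen there. Also open, on these data alone, is whether the same exchange would read alike on the background of compound 1, as this single pair speaks only for the background of compound 2.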